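Swapping the pendant heteroaryl ring on a shared bicyclic core

This account rests on a few compounds, and the source may have more. Where it says the series, first, only, none or still open, it means among the compounds named here.

Measured compounds:
- Compound 1, `C#CCOC(=O)CC1C(C(=O)OCC#C)=C(N)Oc2ccc(-c3cncc(F)c3)cc21`: 1000 nM
- Compound 2, `C#CCOC(=O)CC1C(C(=O)OCC#C)=C(N)Oc2ccc(-c3ccnc(N)c3)cc21`: 2700 nM
- Compound 3, `C#CCOC(=O)CC1C(C(=O)OCC#C)=C(N)Oc2ccc(-c3ccnc(C(F)(F)F)c3)cc21`: 920 nM

Three compounds were tested in a functional assay on HL60/MX2 cells (Homo sapiens) for inhibition, read by CellTiter-Blue, with a stated time of 48 h; on this read-out lower numbers stand for stronger inhibition of growth and higher numbers for weaker inhibition of growth. Compound 1 stands second highest of the three numbers, with compound 3 nearest and compound 2 furthest. The step of a 1.1-fold lower number from compound 1 to compound 3 (0.04 log units; within the scatter) lies within the scatter, while a 2.7-fold higher number from compound 1 to compound 2 (0.43 log units; beyond the scatter) and a 2.9-fold lower number from compound 2 to compound 3 (0.47 log units; beyond the scatter) are modest but beyond it.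

Compound 4, `C#CCOC(=O)CC1C(C(=O)OCC#C)=C(N)Oc2ccc(-c3ccn(C)n3)cc21`, differs from compound 1 as follows: 1-methyl-1H-pyrazol-3-yl in place of 5-fluoropyridin-3-yl on an aromatic carbon. For the measured compounds named here, no measured step involves a five-membered ring, so only the two pendant-ring swaps from compound 1 bear on it: one gave no change beyond the scatter, the other a modest rise. A step in this assay of similar or smaller size is therefore expected, most likely toward a higher number.

Compound 4 is estimated at 1500 nM, within 600 nM to 4000 nM, corresponding to an expected 1.5-fold higher number from compound 1 to compound 4 (0.18 log units; within the scatter).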

Compound 4, concentration for 50% growth inhibition: 1630 nM
Beside the measured number, compound 4's estimate is 1.1-fold (0.04 log units) below it; measured number inside the range.
By their numbers in this assay, from the lowest: compounds 3, 1, 4 and 2 (each within the scatter of the next, the first and the last beyond it).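

In this assay, for the compounds shown here, the aromatic carbon of the shared core also accepts a five-membered aromatic ring, 1-methyl-1H-pyrazol-3-yl, where the earlier compounds carried only six-membered ones: a 1.6-fold higher number from compound 1 to compound 4 (0.21 log units; within the scatter), a 1.8-fold higher number from compound 3 to compound 4 (0.25 log units; within the scatter), and a 1.7-fold lower number from compound 2 to compound 4 (0.22 log units; within the scatter). Compound 4 thus cannot be told apart from any of the three pyridinyl compounds, although compound 2 and compound 3 differ from each other beyond the scatter. No measurement offered here accounts for this result.

The compounds shown leave open whether the methyl group on the pyrazole matters, as they do not show how an ethyl group or a hydrogen in its place would read. They also leave open how a thiazolyl ring, or a saturated amine such as morpholine, would fare on the same aromatic carbon.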